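Acetamido for Cyano on the Trifluoromethyl Core

The source may report more compounds than this note shows. Statements on the series, on what has been measured and on what is new or still open speak of the compounds shown alone.

Measured so far:
compound 1 `N#Cc1ccc(S(=O)(=O)N2C/C(=C\c3cccnc3)C(=O)/C(=C/c3ccccc3F)C2)cc1` 15800 nM
compound 2 `CC(=O)Nc1ccc(S(=O)(=O)N2C/C(=C\c3cccnc3)C(=O)/C(=C/c3ccccc3F)C2)cc1` 9640 nM
compound 3 `N#Cc1ccc(S(=O)(=O)N2C/C(=C\c3cccnc3)C(=O)/C(=C/c3ccccc3C(F)(F)F)C2)cc1` 6150 nM

Three compounds were tested in a functional assay on QGY-7703 cells (Homo sapiens) for cytotoxicity, read by MTT assay, with a stated time of 24 h; on this read-out lower numbers stand for stronger inhibition and higher numbers for weaker inhibition. Compound 2 differs from compound 1 in one place, (acetamido in place of cyano on an aromatic carbon), and this gave a 1.6-fold lower number from compound 1 to compound 2 (0.21 log units; within the scatter). Compound 3 differs from compound 1 in another place, (trifluoromethyl in place of fluoro on an aromatic carbon), and this gave a 2.6-fold lower number from compound 1 to compound 3 (0.41 log units; beyond the scatter). Compound 3 stands lowest of the three, though its distance from compound 2 is within the scatter, so no order between those two can be claimed.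

Compound 4 `CC(=O)Nc1ccc(S(=O)(=O)N2C/C(=C\c3cccnc3)C(=O)/C(=C/c3ccccc3C(F)(F)F)C2)cc1` has not yet been measured in this assay. It differs from compound 3 by acetamido in place of cyano on an aromatic carbon. This is the same change as from compound 1 to compound 2, at the same place, and the cores of the two pairs differ only in the way already described for compound 1 and compound 3. The step is therefore expected to be about a 1.5-fold lower number from compound 3 to compound 4 (0.19 log units; within the scatter), a small one, because a 1.6-fold lower number from compound 1 to compound 2 (0.21 log units; within the scatter) was itself within the scatter. Compound 4 is estimated to give 4000 nM, most likely between 2000 nM and 8000 nM.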

Compound 4, half-maximal inhibitory concentration: 5380 nM
Beside the measured number, compound 4's estimate is 1.3-fold (0.13 log units) below it; low and high end bracket the measured number.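

In this assay, acetamido in place of cyano on the trifluoromethyl core gave a 1.1-fold lower number from compound 3 to compound 4 (0.06 log units; within the scatter), and this step does not differ from the one seen on the core of compound 1: the same change on two cores in this assay, a 1.6-fold lower number (0.21 log units; within the scatter) from compound 1 to compound 2 and a 1.1-fold lower number (0.06 log units; within the scatter) from compound 3 to compound 4, 1.4-fold (0.16 log units) apart, within the scatter of two such steps. Read the other way round, trifluoromethyl in place of fluoro on the acetamido core gave a 1.8-fold lower number from compound 2 to compound 4 (0.25 log units; within the scatter), and this step also agrees with its earlier counterpart: the same change on two cores in this assay, a 2.6-fold lower number (0.41 log units; beyond the scatter) from compound 1 to compound 3 and a 1.8-fold lower number (0.25 log units; within the scatter) from compound 2 to compound 4, 1.4-fold (0.16 log units) apart, within the scatter of two such steps. Within the data shown here, both changes therefore carry from one core to the other without a detectable difference, but each comparison rests on a single pair, the acetamido step stays within the scatter on both cores and so shows no clear effect of its own, and the trifluoromethyl step passes beyond the scatter on only one core.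

The compounds shown leave open whether this agreement extends to other groups in place of cyano, such as a primary amine or a carboxylic acid. They also leave open whether it would hold with chloro or methoxy in place of fluoro.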